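The compounds below may be only part of what the source reports. "The series", "measured", "known", "first", "only" and "open" are said of these compounds alone.

Measured so far in an ADME assay on THP-1 cells (Homo sapiens) for cytotoxicity, read by MTT assay, with a stated time of 72 h; on this read-out lower numbers stand for higher toxicity in this test and higher numbers for lower toxicity in this test:

- compound 1 `COc1cc(OC)cc(-c2cn(Cc3cc(-c4ccccc4)no3)nn2)c1`: 143000 nM
- compound 2 `COc1ccc(-c2cc(Cn3cc(-c4cc(OC)cc(OC)c4)nn3)on2)cc1`: "not determined" (no result reported)
- compound 3 `COc1ccc(-c2cc(Cn3cc(-c4cc(C)c(C)cc4C)nn3)on2)cc1OC`: > 500000 nM

Only compound 1 has an exact number here, and compound 2 has no result at all. For compound 3, the entry > 500000 nM is a limit of the assay and not a number. This makes compound 3 an uncertain starting point, since its true value is not known.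

Compound 4 `COc1cc(OC)cc(-c2cn(Cc3cc(-c4ccc(OC)c(OC)c4)no3)nn2)c1` has not yet been measured. It differs from compound 3 at one place, with 3,5-dimethoxyphenyl in place of 2,4,5-trimethylphenyl on an aromatic carbon of a five-membered aromatic ring with 3 nitrogen (3,5-dimethoxyphenyl in place of 2,4,5-trimethylphenyl on an aromatic carbon).

For the measured compounds named here, no measured pair in this small set isolates this change, so any forecast rests on thin evidence. The closest guide is compound 1, which also carries 3,5-dimethoxyphenyl and gives 143000 nM. On that basis, a moderate move toward lower numbers, meaning higher toxicity in this test, is expected rather than no change. The expected size is an at least 2.5-fold lower number from compound 3 to compound 4 (0.39 log units; beyond the scatter), and this estimate is loose. For compound 4 the estimated value is 200000 nM, with an expected range of 70000 nM to 450000 nM.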

Compound 4, half-maximal cytotoxic concentration: > 500000 nM
Compound 4 was reported as a limit (the forecaster's own chance of this, stated with the estimate: 25%); middle value at least 2.5-fold (0.39 log units) away from the limit.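

In this assay, the change from 2,4,5-trimethylphenyl to 3,5-dimethoxyphenyl cannot be read, since compound 3 and compound 4 both end at a limit of the assay and not at a number: the limit of > 500000 nM in this assay, at which 2 of the 4 values shown sit.

The readable result comes from a different place on the molecule, where 3,4-dimethoxyphenyl in place of phenyl gives an at least 3.4-fold higher number from compound 1 to compound 4 (0.54 log units; beyond the scatter), which means lower toxicity in this test. Compound 1 and compound 4 both carry 3,5-dimethoxyphenyl, so that group alone does not set the read-out, and the group at the second place matters as well.

As far as these compounds go, how compound 3 and compound 4 truly compare stays open, and so does the size of the step from compound 1 beyond its stated minimum. Also open, from the compounds shown here alone, is whether an amine or a carboxylic acid in place of either aromatic group would bring the number back within the range that the assay can measure.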